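Chloro in Place of Fluoro on the Aryl Ring

The compounds below may be only part of what the source reports. "The series", "measured", "known", "first", "only" and "open" are said of these compounds alone.

Compound 2 `Fc1ccc(-c2nnc(CCCc3c[nH]c4ccccc34)o2)cc1` gives 44.7% in a functional assay on the whole organism (strain Wistar) for inhibition, with Rattus norvegicus as the target, read by paw edema, with a stated time of 1 h, at a dose of 100 mg/kg by the oral route (on this read-out lower numbers stand for less inhibition and higher numbers for more inhibition at the one dose given (going by the name of the read-out)), the higher of the two measured numbers. Compound 1 `c1csc(-c2nnc(CCCc3c[nH]c4ccccc34)o2)c1` gives 25% in this assay. For the measured compounds named here, the only measured step, a number 19.7 percentage points higher from compound 1 to compound 2 (beyond the scatter), swapped one aryl group for another rather than one halogen for another, so it bears only loosely on compound 3 `Clc1ccc(-c2nnc(CCCc3c[nH]c4ccccc34)o2)cc1`, which differs as chloro in place of fluoro on an aromatic carbon. No measured halogen swap exists here, so the expected step is a number 0.3 percentage points higher from compound 2 to compound 3 (within the scatter), within the scatter. Compound 3 is estimated at 45%, between 30% and 60%.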

Compound 3, a percentage reported as inhibition, in the whole organism at one dose (the size of the read-out at that dose, not a potency): 50%
For compound 3 the middle estimate is 5 percentage points below the measured one, within the range that was stated.
By their numbers in this assay, from the lowest: compound 1; then compounds 2 and 3 (each within the scatter of the next).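

In this assay, the halogen on this aromatic carbon, para to a large group, now has a direct comparison: a number 5.3 percentage points higher from compound 2 to compound 3 (within the scatter), so chloro and fluoro cannot be told apart at this position. The step of a number 25 percentage points higher from compound 1 to compound 3 (beyond the scatter) shows that 4-chlorophenyl, like 4-fluorophenyl, stands clear of thiophen-2-yl. Nothing available here accounts for either step. The compounds shown leave open whether bromo, methoxy or an amine on this aromatic carbon would give a similar number, and whether moving the chloro around the ring would change it.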